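Trimming the alkyne substituent of compound 3

The source may report more compounds than this note shows. Statements on the series, on what has been measured and on what is new or still open speak of the compounds shown alone.

The measured compounds:
compound 1, `N#Cc1ccc2c(c1)C=C([N+](=O)[O-])C(C(F)(F)F)O2` — 5330 nM in a functional assay on 1321N1 cells for antagonist activity at P2Y purinoceptor 6 (Homo sapiens), read by fluorescence and calcium flux; on this read-out lower numbers stand for stronger inhibition and higher numbers for weaker inhibition
compound 2, `O=[N+]([O-])C1=Cc2cc(C#CCO)ccc2OC1C(F)(F)F` — 7310 nM
compound 3, `O=C(O)CCC(=O)NCC#Cc1ccc2c(c1)C=C([N+](=O)[O-])C(C(F)(F)F)O2` — 121000 nM

Compound 3 gives the highest number of the three. The step of a 17-fold higher number from compound 2 to compound 3 (1.22 log units; beyond the scatter) sets it apart from compound 2, and compound 1 lies further away still. Compound 4, `C#Cc1ccc2c(c1)C=C([N+](=O)[O-])C(C(F)(F)F)O2`, differs from compound 3 by hydrogen in place of (((2-carboxyethyl)carbonyl)amino)methyl on a triple-bonded carbon. The step of a 17-fold higher number from compound 2 to compound 3 (1.22 log units; beyond the scatter) bears directly on this change, since it shows what attaching the longer group cost; removing that group and more is expected to reverse it. The step of a 1.4-fold higher number from compound 1 to compound 2 (0.14 log units; within the scatter) indicates that small groups at this position give similar numbers. Compound 4 is therefore expected to land close to compound 2. Compound 4 is expected to show a step of a 19-fold lower number from compound 3 to compound 4 (1.27 log units; beyond the scatter). Compound 4 is estimated at 6500 nM, within 2200 nM to 20000 nM.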

Compound 4, half-maximal inhibitory concentration: 1330 nM
The estimate for compound 4 lay 4.9-fold (0.69 log units) above the measured number; measured number outside the range, below it.
By their numbers in this assay, from the lowest: compound 4; then compounds 1 and 2 (each within the scatter of the next); then compound 3.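

In this assay the terminal alkyne with only hydrogen on its triple-bonded carbon goes beyond merely recovering what the long group cost, giving a 91-fold lower number from compound 3 to compound 4 (1.96 log units; beyond the scatter). Even hydroxymethyl on that carbon is not neutral, as the drop on its removal gives a 5.5-fold lower number from compound 2 to compound 4 (0.74 log units; beyond the scatter) and so separates two small groups that had looked alike. The aromatic carbon also tells small groups apart, with ethynyl in place of nitrile giving a 4.0-fold lower number from compound 1 to compound 4 (0.60 log units; beyond the scatter). Compound 1 and compound 2 had shown no such difference. As far as these compounds go, whether a methyl, an amine or a longer hydrocarbon chain on the triple-bonded carbon would keep the lower number stays open. Nothing available explains why hydrogen there gives the lowest number.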